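This account rests on a few compounds, and the source may have more. Where it says the series, first, only, none or still open, it means among the compounds named here.

In a physicochemical assay for permeability, using PAMPA, at pH 7.4 (a lower number here means that the compound crosses the layer more slowly, a higher number that the compound crosses the layer faster), the three measured compounds stand as follows: compound 1 `CC(C)NCCS(=O)(=O)NC(=O)c1ccc(Nc2nc(NC3(c4ccc(Cl)cc4)CC3)nc(OCC(F)(F)F)n2)cc1` gives 45 nm/s; compound 2 `CC(C)C(=O)NCCS(=O)(=O)NC(=O)c1ccc(Nc2nc(NC3(c4ccc(Cl)cc4)CC3)nc(OCC(F)(F)F)n2)cc1` gives 13 nm/s; compound 3 `CC(=O)NCCS(=O)(=O)NC(=O)c1ccc(Nc2nc(NC3(c4ccc(Cl)cc4)CC3)nc(OCC(F)(F)F)n2)cc1` gives 7 nm/s.

Compound 3 has the lowest of the three numbers. Its gap to compound 2 is small, a 1.9-fold lower number from compound 2 to compound 3 (0.27 log units; within the scatter), which is within the scatter, so no order between compound 2 and compound 3 can be claimed. The larger gap is the step of a 6.4-fold lower number from compound 1 to compound 3 (0.81 log units; beyond the scatter), which is beyond the scatter.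

Compound 4 `CNC(=O)NCCS(=O)(=O)NC(=O)c1ccc(Nc2nc(NC3(c4ccc(Cl)cc4)CC3)nc(OCC(F)(F)F)n2)cc1` differs from compound 3 in one place: methylamino in place of methyl on a carbonyl carbon. Within the data shown here, no measured step repeats this exact change. Among the measured compounds shown here, two steps bear on it indirectly, both replacing the isopropyl on the amine nitrogen of compound 1 with a carbonyl-bearing group: a 3.5-fold lower number from compound 1 to compound 2 (0.54 log units; beyond the scatter) and a 6.4-fold lower number from compound 1 to compound 3 (0.81 log units; beyond the scatter). Both lowered the number in this assay by a modest amount. For the measured compounds named here, the one step that alters only the group on the carbonyl carbon, a 1.9-fold lower number from compound 2 to compound 3 (0.27 log units; within the scatter), stayed within the scatter. A further change at that carbon is therefore expected to move the number little, at most a small decrease, a 1.4-fold lower number from compound 3 to compound 4 (0.15 log units; within the scatter). Compound 4 is estimated at 5 nm/s in this assay, with a range from 2 nm/s to 12 nm/s.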

Compound 4, apparent permeability: 40 nm/s
The estimate for compound 4 lay 8.0-fold (0.90 log units) below the measured number, outside the stated range (above it).
By their numbers in this assay, from the lowest: compounds 3 and 2 (each within the scatter of the next); then compounds 4 and 1 (each within the scatter of the next).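

In this assay, the group on the carbonyl carbon proves able to move the number after all: methylamino in place of methyl gives (a 5.7-fold higher number from compound 3 to compound 4 (0.76 log units; beyond the scatter)) and methylamino in place of isopropyl gives (a 3.1-fold higher number from compound 2 to compound 4 (0.49 log units; beyond the scatter)), whereas the earlier exchange of isopropyl for methyl at that carbon stayed within the scatter. A carbonyl on the amine nitrogen therefore does not go with a lower number in every case: methylcarbamoyl in place of isopropyl gives (a 1.1-fold lower number from compound 1 to compound 4 (0.05 log units; within the scatter)), so compound 4 cannot be separated from compound 1, while compound 2 and compound 3, with their isopropylcarbonyl and acetyl groups, go against any rule built on compound 4 alone. Nothing measured here gives a reason for this difference between methylamino and the two carbon groups.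

The compounds shown leave open whether the nitrogen of methylamino or its hydrogen goes with the higher number, which dimethylamino or methoxy on the same carbonyl carbon could separate. They also leave open whether a longer chain on that nitrogen, such as ethylamino or propylamino, would keep the number where compound 4 stands.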